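Swapping the Aromatic Ester Partner at the Assay Limit

The source may hold more compounds than are shown below. What is called first, only, known or untested is meant among the compounds shown, and "the series" means these compounds.

Of the compounds shown here, three sharing one core have been tested so far. Going by the values given here, compound 1 `O=C(NCc1ccccc1)c1cn(-c2ccccc2)nc1-c1cccnc1` is the first of them. In a functional assay on HeLa cells (Homo sapiens) for cytotoxicity, read by MTT assay, with a stated time of 48 h (on this read-out higher numbers stand for weaker inhibition and lower numbers for stronger inhibition), compound 1 gives only a limit of the assay, > 100000 nM. Among the compounds with values here, compound 2 `O=C(c1cn(-c2ccccc2)nc1-c1cccnc1)N1CCC(Cc2ccccc2)CC1` is the only one with an actual number: in this assay compound 2 gives 25300 nM. Compound 3 `CC(C)c1cccc(OC(=O)c2cn(-c3ccccc3)nc2-c2cccnc2)c1`, which carries a 3-isopropylphenyl group on an oxygen, again reaches no number. In this assay compound 3 gives a limit of the assay, > 100000 nM. Compound 3 therefore stands at the weak end of what has been seen, alongside the other limit; two of the three values shown sit there (the limit of > 100000 nM in this assay, at which 2 of the 3 values shown sit), and nothing distinguishes compound 3 from compound 1 on this read-out.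

Compound 4 `O=C(Oc1ccc2ccccc2c1)c1cn(-c2ccccc2)nc1-c1cccnc1` differs from compound 3 in one place: naphthalen-2-yl in place of 3-isopropylphenyl on an oxygen next to a carbonyl group. No measured step between any two of these compounds exists, so the effect of this swap cannot be read from a neighbour. Since compound 3 sits at the limit > 100000 nM, the expectation is that compound 4 stays weak as well. The change is expected to amount to a step that the limit leaves unreadable from compound 3 to compound 4, nothing beyond the scatter. Compound 4 is expected to give about 120000 nM in this assay, somewhere between 30000 nM and 500000 nM.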

Compound 4, half-maximal inhibitory concentration: > 100000 nM
Compound 4: a limit, no number (the forecaster's own chance of this, stated with the estimate: 70%); the middle value is on the limit's open side.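

Going by these compounds alone, compound 3 and compound 4 each give only a limit of the assay in this assay, so no step between them can be read. The compounds shown leave open whether naphthalen-2-yl in place of 3-isopropylphenyl changes the activity at all, since most results now rest on one limit: the limit of > 100000 nM in this assay, at which 3 of the 4 values shown sit.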